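Swapping Methoxy for Fluoro: What Inhibition to Expect

The source may report more compounds than this note shows. Statements on the series, on what has been measured and on what is new or still open speak of the compounds shown alone.

Compound 1 `COc1cccc(OC(=O)c2cc(O)c(O)c(O)c2)c1OC(=O)c1cc(O)c(O)c(O)c1` was tested in a functional assay on NCI-H1299 cells (Homo sapiens) for inhibition, read by scintillation counting, with a stated time of 30 min, tested at 30 uM (on this read-out lower numbers stand for less inhibition and higher numbers for more inhibition at the one concentration tested (going by the name of the read-out)), where compound 1 gives 58.4%. Within the data shown here, of the two numbers in hand this is the lower one; the only other compound, compound 2 `O=C(Oc1ccc(Cl)cc1OC(=O)c1cc(O)c(O)c(O)c1)c1cc(O)c(O)c(O)c1`, gives 84.4% in this assay, a gap beyond the usual scatter. Compound 3 `O=C(Oc1cccc(F)c1OC(=O)c1cc(O)c(O)c(O)c1)c1cc(O)c(O)c(O)c1` has not yet been measured. It differs from compound 1 in one place: fluoro in place of methoxy on an aromatic carbon. Among the measured compounds shown here, no measured pair shows what this change does, so the expected step is small, a number 3.6 percentage points higher from compound 1 to compound 3 (within the scatter), and could fall either way within the scatter. Compound 3 is therefore expected to give about 62%, in a range from 42% to 82%.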

Compound 3, a percentage reported as inhibition, at one concentration (the size of the read-out at that concentration, not a potency): 81.1%
For compound 3 the middle estimate is 19.1 percentage points below the measured one; low and high end bracket the measured number.
By their numbers in this assay, from the lowest: compound 1; then compounds 3 and 2 (each within the scatter of the next).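

Putting fluoro in place of methoxy on this aromatic carbon gives a number 22.7 percentage points higher from compound 1 to compound 3 (beyond the scatter) in this assay. This pair shows that the group at this position matters for the read-out, and that this particular swap raises it. No measurement at hand explains the rise.

The compounds shown leave open whether the gain comes from losing methoxy or from gaining fluoro. A plain hydrogen or an amine on the same carbon would help separate those two readings.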